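Alkynyl-uracil series: butylphenyl analogue of compound 1

The source may hold more compounds than are shown below. What is called first, only, known or untested is meant among the compounds shown, and "the series" means these compounds.

Measured so far:
compound 1, `Cc1ccc(C#Cc2cn(C/C=C\CN3C(=O)c4ccccc4C3=O)c(=O)[nH]c2=O)cc1`, 245000 nM
compound 2, `O=C1c2ccccc2C(=O)N1C/C=C/Cn1cc(C#CCCc2ccccc2)c(=O)[nH]c1=O`, 44000 nM

Both compounds were read in a functional assay on L1210 cells (Mus musculus) for antiproliferative activity, read by MTT assay, with a stated time of 2 days; on this read-out higher numbers stand for weaker inhibition and lower numbers for stronger inhibition. Compound 1 stands at the highest of the two numbers; the nearest value, that of compound 2, is lower, and the gap between the two lies beyond the scatter. Among the compounds with values here, the two differ in more than one place, so their values show only that compound 2 inhibits more strongly than compound 1, nothing more.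

Compound 3, `CCCCc1ccc(C#Cc2cn(C/C=C\CN3C(=O)c4ccccc4C3=O)c(=O)[nH]c2=O)cc1`, is not yet measured. It arises from compound 1 by propyl in place of hydrogen on a saturated chain carbon bound to an aromatic carbon, so the shared core carries a 4-butylphenyl instead of a 4-methylphenyl on the alkyne. Within the data shown here, no directly comparable step is at hand. In this assay a modest move toward stronger inhibition is expected, at most a few steps beyond the scatter, as a 2.5-fold lower number from compound 1 to compound 3 (0.39 log units; beyond the scatter). For compound 3 the estimate is 100000 nM, within 30000 nM to 300000 nM.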

Compound 3, half-maximal inhibitory concentration: 31000 nM
The estimate for compound 3 lay 3.2-fold (0.51 log units) above the measured number, and the stated range covers the measured number.
By their numbers in this assay, from the lowest: compounds 3 and 2 (each within the scatter of the next); then compound 1.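

Within the data shown here, this is the first single-place step: in this assay, methyl to butyl on the alkyne-bound aryl group, with 4-methylphenyl becoming 4-butylphenyl, gives a 7.9-fold lower number from compound 1 to compound 3 (0.90 log units; beyond the scatter). The saturated chain carbon bound to an aromatic carbon therefore accepts the added propyl without loss of inhibition, and this change strengthens inhibition beyond the scatter, which the comparison of compound 1 with compound 2 could not show because those two differ in more than one place. Nothing at hand accounts for the size or direction of this step, which remains a single observation and not a trend with chain length.

From the compounds shown here alone, with only methyl and butyl at this position, the shape of the chain-length response remains open: an ethyl or a hexyl chain could show whether inhibition keeps strengthening, levels off or reverses. Also open, going by these compounds, is whether the gain depends on a plain hydrocarbon chain, which a terminal amine or carboxylic acid on the butyl chain would test, and whether it carries over to the other alkene geometry on the shared core.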